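The compounds below may be only part of what the source reports. "The series", "measured", "known", "first", "only" and "open" are said of these compounds alone.

Measured so far in an assay on Sf9 cells for inhibition of protein deacetylase HDAC6 (Homo sapiens), read by fluorescence, with a stated time of 40 min, tested at 100 nM; a higher number here means more inhibition at the concentration tested (going by the name of the read-out), a lower number less inhibition:
compound 1, `O=C(NO)c1ccc(NCc2nc(-c3ccc(Br)o3)nn2-c2ccccc2)cc1`: 55.8%
compound 2, `O=C(NO)c1ccc(NCc2nc(-c3ccc(Cl)cc3)nn2-c2ccccc2)cc1`: 67.2%

Among the measured compounds shown here, compound 2 gives the higher of the two numbers in this assay; its nearest neighbour is compound 1, and the one measured step, a number 11.4 percentage points higher from compound 1 to compound 2 (beyond the scatter), goes with 4-chlorophenyl in place of 5-bromofuran-2-yl on an aromatic carbon. Compound 3, `O=C(NO)c1ccc(NCc2nc(-c3ccc(F)cc3)nn2-c2ccccc2)cc1`, has not yet been measured. It differs from compound 2 in one place: fluoro in place of chloro on an aromatic carbon. The six-membered aromatic ring of carbon only is kept and one halogen stands in for another. For the measured compounds named here, no measured step shows this exchange directly: the only recorded step, a number 11.4 percentage points higher from compound 1 to compound 2 (beyond the scatter), changes the ring as well as the halogen, so it bears on the question only loosely and gives no direction for a change within the 4-halophenyl series. A step of about the size of the scatter, perhaps slightly downward, is therefore the expectation in this assay. Compound 3 is expected to give 60%, within a range from 45% to 75%. This corresponds to an expected step of a number 7.2 percentage points lower from compound 2 to compound 3 (within the scatter).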

Compound 3, a percentage reported as inhibition, at one concentration (the size of the read-out at that concentration, not a potency): 70.9%
Compound 3: middle estimate off by 10.9 percentage points, on the low side; the measured number falls inside the stated range.
By their numbers in this assay, from the lowest: compound 1; then compounds 2 and 3 (each within the scatter of the next).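

In this assay, among the compounds shown here, the exchange of chloro for fluoro on an aromatic carbon, para to a large group, gives the first direct reading of one halogen against another with the six-membered ring kept: a number 3.7 percentage points higher from compound 2 to compound 3 (within the scatter) and so does not separate the two halogens at this position. The 4-fluorophenyl group also stands apart from 5-bromofuran-2-yl, with a number 15.1 percentage points higher from compound 1 to compound 3 (beyond the scatter) in the same assay, so both 4-halophenyl compounds now give higher numbers than compound 1, and neither goes against this within the three compounds shown. The compounds shown offer no measurement that accounts for either step.

As far as these compounds go, it remains open whether the number in this assay would be higher, lower or level with groups other than chloro and fluoro at this position, such as an amine, a methoxy group, a nitrile or a plain hydrogen. Also open, from the compounds shown here alone, is how much of the difference from compound 1 belongs to the furan ring and how much to the bromine, which a 4-bromophenyl group or a 5-chlorofuran-2-yl group would help to separate.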